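Swapping the pyrazole of compound 3 for a substituted imidazole

A few compounds are considered here, and "the series" means these few. Any claim that something is new, unique, unknown or untested is made for them only; others in the source may bear on it.

Compounds measured so far:
compound 1, `Cc1nc(CN2CCN(c3cccc4[nH]c(-c5ccc(C(C)(C)C)cc5)nc34)CC2)c[nH]1`, 7.5 nM
compound 2, `CCc1nc(C)c(CN2CCN(c3cccc4[nH]c(-c5ccc(C(C)(C)C)cc5)nc34)CC2)o1`, 37 nM
compound 3, `Cc1cc(CN2CCN(c3cccc4[nH]c(-c5ccc(C(C)(C)C)cc5)nc34)CC2)nn1C`, 83 nM

All three share one core, and they differ only in the small aromatic ring attached on a saturated chain carbon bound to an amine nitrogen in a ring. In an assay on isolated protein for displacement of a labelled ligand from Gonadotropin-releasing hormone receptor (Homo sapiens) (on this read-out higher numbers stand for weaker inhibition and lower numbers for stronger inhibition), compound 3 stands at the highest number of the three, that is, it is the weakest binder shown: the step of a 2.2-fold higher number from compound 2 to compound 3 (0.35 log units; beyond the scatter) is modest, while an 11-fold higher number from compound 1 to compound 3 (1.04 log units; beyond the scatter) is large.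

Compound 4, `CCCCc1nc(CN2CCN(c3cccc4[nH]c(-c5ccc(C(C)(C)C)cc5)nc34)CC2)cn1C`, carries the change (2-butyl-1-methyl-1H-imidazol-4-yl in place of 1,5-dimethyl-1H-pyrazol-3-yl on a saturated chain carbon bound to an amine nitrogen in a ring). The entering ring is an imidazole, as in compound 1, but bears a 2-butyl and a 1-methyl group instead of compound 1's 2-methyl group. For the measured compounds named here, the step from the 2-methyl-1H-imidazol-4-yl of compound 1 to the pyrazole of compound 3, an 11-fold higher number from compound 1 to compound 3 (1.04 log units; beyond the scatter), is the one measured step that bears directly on this move, and it runs in the opposite direction. Returning to an imidazole is therefore expected to lower the number, but the added butyl and methyl groups have no measured counterpart, so the expected step of a 2.8-fold lower number from compound 3 to compound 4 (0.44 log units; beyond the scatter) is kept smaller than the full reversal.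

For compound 4 in this assay the estimate is 30 nM, with a range from 8 nM to 120 nM.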

Compound 4, half-maximal inhibitory concentration: 26 nM
Compound 4: middle estimate off by 1.2-fold (0.06 log units), on the high side; measured number inside the range.
By their numbers in this assay, from the lowest: compound 1; then compounds 4 and 2 (each within the scatter of the next); then compound 3.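

In this assay, the position on a saturated chain carbon bound to an amine nitrogen in a ring tolerates a clearly larger group: 2-butyl-1-methyl-1H-imidazol-4-yl has 10 heavy atoms against 7 for the 1,5-dimethyl-1H-pyrazol-3-yl it replaces, yet the change gives a 3.2-fold lower number from compound 3 to compound 4 (0.50 log units; beyond the scatter) rather than a loss of binding. Having an imidazole at this position does not fix the number on its own, as the two imidazoles still show a 3.5-fold higher number from compound 1 to compound 4 (0.54 log units; beyond the scatter) and the substituents on the ring are what separate them. Compound 4 also cannot be told apart from the oxazole-bearing compound 2, with a 1.4-fold lower number from compound 2 to compound 4 (0.15 log units; within the scatter) as their step, and nothing measured here accounts for any of these steps.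

The compounds shown leave open which of the two added groups, the butyl or the 1-methyl, carries the gap to compound 1, as the two arrive together. They also leave open how an imidazole with a propyl chain, or with a butyl chain ending in an amine, would read in this assay at this position.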